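The source may report more compounds than this note shows. Statements on the series, on what has been measured and on what is new or still open speak of the compounds shown alone.

Working notes on the series. Compound 1 `CCOC(=O)/C(=C/c1ccccc1)CN1C(=O)[C@@H](OC)[C@H]1c1ccc(Cl)cc1`, compound 2 `CO[C@@H]1C(=O)N(C/C(C#N)=C/c2ccccc2)[C@@H]1c1ccc(Cl)cc1Cl` and compound 3 `COC(=O)/C(=C/c1ccccc1)CN1C(=O)[C@@H](OC)[C@H]1c1cccc(F)c1` share one core. In a functional assay on MCF7 cells (Homo sapiens) for antiproliferative activity, read by MTT assay, with a stated time of 48 h (a higher number here means a weaker inhibitor, a lower number a stronger inhibitor), compound 1 gives 12700 nM. Compound 2 gives 31900 nM in this assay. Compound 3 gives 13700 nM in this assay; compound 3 and compound 1 lie within the scatter of each other, while compound 2 gives a number higher than that of compound 3 by more than the scatter. Compound 4 `COC(=O)/C(=C/c1ccccc1)CN1C(=O)[C@@H](OC)[C@H]1c1ccc(F)cc1` is not yet measured and differs from compound 3 in one place: 4-fluorophenyl in place of 3-fluorophenyl on a saturated ring carbon. Among the measured compounds shown here, no measured pair here differs by a single change, so no step size is known; the expectation is a change no larger than the scatter. For compound 4 the estimate in this assay is 14000 nM, ranging from 6000 nM to 35000 nM. The expected step of a 1.0-fold higher number from compound 3 to compound 4 (0.01 log units; within the scatter) is thus small.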

Compound 4, half-maximal inhibitory concentration: 15600 nM
Compound 4: middle estimate off by 1.1-fold (0.05 log units), on the low side, and the stated range covers the measured number.
By their numbers in this assay, from the lowest: compounds 1, 3 and 4 (each within the scatter of the next); then compound 2.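

Among the compounds shown here, the first single-change step in this assay is a 1.1-fold higher number from compound 3 to compound 4 (0.06 log units; within the scatter), for 4-fluorophenyl in place of 3-fluorophenyl on the saturated ring carbon. For the compounds shown here, at this position, the two fluorophenyl groups therefore cannot be told apart in this read-out, which the earlier compounds, none a single change from another, could not show. Nothing available bears on the reason for this result. Still open, from the compounds shown here alone, is whether a different group on this carbon, such as a phenyl ring carrying an amine or a carboxylic acid, would give a step beyond the scatter.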